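This account rests on a few compounds, and the source may have more. Where it says the series, first, only, none or still open, it means among the compounds named here.

Measured in a functional assay on MCF7 cells (Homo sapiens) for inhibition, read by sulforhodamine B assay, with a stated time of 48 h; a lower number here means a stronger inhibitor of growth, a higher number a weaker inhibitor of growth:
Compound 1 `O=C(CCl)NC(=O)Nc1ccc(C2CCCCC2)cc1`: 1500 nM
Compound 2 `O=C(CCl)NC(=O)Nc1ccc(OC2CCCCC2)cc1`: 4700 nM
Compound 3 `Cc1ccc(NC(=O)NC(=O)CCl)cc1`: 7500 nM

Compound 3 has the highest number of the three, though its nearest neighbour is within the scatter: a 1.6-fold higher number from compound 2 to compound 3 (0.20 log units; within the scatter). Its furthest neighbour is clearly apart: a 5.0-fold higher number from compound 1 to compound 3 (0.70 log units; beyond the scatter). Compound 4 `Cc1ccc(NC(=O)NC(=O)CCl)cc1C` carries methyl in place of hydrogen on an aromatic carbon, ortho to a methyl group and meta to a group of 8 heavy atoms (methyl in place of hydrogen on an aromatic carbon). Among the compounds with values here, no measured step makes this exact change. The closest guide is the modest step of a 5.0-fold higher number from compound 1 to compound 3 (0.70 log units; beyond the scatter), where a larger group replaces the methyl, so only a small shift towards a lower number is expected in this assay. The expected step is a 1.4-fold lower number from compound 3 to compound 4 (0.13 log units; within the scatter). For compound 4 the estimated value is 5500 nM, with an expected range of 2500 nM to 12000 nM.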

Compound 4, concentration for 50% growth inhibition: 5500 nM
Compound 4: middle estimate and measured number agree at the digits printed; the measured number falls inside the stated range.
By their numbers in this assay, from the lowest: compound 1; then compounds 2, 4 and 3 (each within the scatter of the next).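

In this assay, methyl in place of hydrogen on an aromatic carbon, ortho to a methyl group and meta to a group of 8 heavy atoms, gives a 1.4-fold lower number from compound 3 to compound 4 (0.13 log units; within the scatter). Within the data shown here, the earlier compounds differed only in one group, so compound 4 is the first to show that this second position can carry a methyl group with a step inside the scatter. No measurement at hand accounts for this result. Going by these compounds, what an ethyl group, an amine or a carboxylic acid would do at this position remains open. So does whether this methyl would give a similar step alongside the cyclohexyl group of compound 1.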